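Indolyl for furanyl in a cytotoxicity series of limits

The source may hold more compounds than are shown below. What is called first, only, known or untested is meant among the compounds shown, and "the series" means these compounds.

Compound 1 `CC(C)N(Cc1cccc(OCCCCCC(=O)O)c1)C(=O)c1ccccc1`, compound 2 `CC(C)N(Cc1cccc(OCCCCCC(=O)O)c1)C(=O)c1ccc(-c2ccoc2)cc1` and compound 3 `CC(C)N(Cc1cccc(OCCCCCC(=O)O)c1)C(=O)c1ccc(-c2cccc(Oc3ccccc3)c2)cc1` share one core and differ only in the group carried on one aromatic carbon. In an ADME assay on Raji cells (Homo sapiens) for cytotoxicity, read by CellTiter-Glo and resazurin assay, with a stated time of 72 h (a lower number here means that less compound is needed, a higher number that more compound is needed for the effect), compound 1 reaches only the limit of the assay, > 26000 nM. In this assay compound 2 likewise returns only a limit, > 26000 nM. Compound 3 also gives only a limit, > 18700 nM. Within the data shown here, the one step between neighbours, a step that the two limits leave unreadable from compound 1 to compound 2, is therefore not readable in size. Among the measured compounds shown here, compound 2 stands at the limit of > 26000 nM in this assay, at which 2 of the 3 values shown sit; the remaining value sits at the limit of > 18700 nM in this assay, at which 1 of the 3 values shown sits, so no compound in the set shows a numeric value at all.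

Compound 4 `CC(C)N(Cc1cccc(OCCCCCC(=O)O)c1)C(=O)c1ccc(-c2ccc3cc[nH]c3c2)cc1` differs from compound 2 by 1H-indol-6-yl in place of furan-3-yl on an aromatic carbon. For the measured compounds named here, no measured step bears on this change, and the only step available is unreadable, so no direction can be drawn from the data. Compound 4 is therefore expected to remain at or near the limit, with an estimate of 30000 nM and a range from 8000 nM to 100000 nM. The expected step is a step that the limit leaves unreadable from compound 2 to compound 4, and a second limit rather than a number is considered the more likely outcome for compound 4.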

Compound 4, half-maximal effective concentration: > 26000 nM
Compound 4 ended at the assay's limit; the forecaster's own chance of this, stated with the estimate: 70%; the middle value does not contradict the limit.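

In this assay compound 4, like compound 1 and compound 2, returns only a limit, so no step among these three compounds can be read. The compounds shown leave open at what concentration, if any, each would reach the half-maximal effect on these cells.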